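A Nitro Group Replaces a Hydroxyl on the Aryl Substituent

The source may hold more compounds than are shown below. What is called first, only, known or untested is meant among the compounds shown, and "the series" means these compounds.

Compound 2 `CCCCCCCCCCCCCCCCCCNC(=O)[C@H]1CSC(c2cccc(O)c2)N1` stands lowest of the two measured compounds in a functional assay on DU-145 cells (Homo sapiens) for antiproliferative activity, read by sulforhodamine B assay (a higher number here means a weaker inhibitor, a lower number a stronger inhibitor), giving 5700 nM. In this assay compound 1 `CCCCCCCCCCCCCCCCCCNC(=O)[C@H]1CSC(Cc2ccccc2)N1` gives 15300 nM; the step of a 2.7-fold lower number from compound 1 to compound 2 (0.43 log units; beyond the scatter) shows that the group on the saturated ring carbon matters. Compound 3 `CCCCCCCCCCCCCCCCCCNC(=O)[C@H]1CSC(c2ccc([N+](=O)[O-])cc2)N1` carries 4-nitrophenyl in place of 3-hydroxyphenyl on a saturated ring carbon. For the measured compounds named here, no measured step exchanges one aromatic group for another, so the single known step is only a weak guide and gives no direction for this exchange. Compound 3 is therefore expected to give about 6000 nM, between 2500 nM and 15000 nM, with the expected step of a 1.1-fold higher number from compound 2 to compound 3 (0.02 log units; within the scatter) staying within the scatter.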

Compound 3, half-maximal inhibitory concentration: 15300 nM
The estimate for compound 3 lay 2.6-fold (0.41 log units) below the measured number; the whole stated range lies below it.
By their numbers in this assay, from the lowest: compound 2; then compounds 1 and 3 (each within the scatter of the next).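

Exchanging one aromatic group for another on this saturated ring carbon does move the number in this assay: 4-nitrophenyl in place of 3-hydroxyphenyl gives a 2.7-fold higher number from compound 2 to compound 3 (0.43 log units; beyond the scatter) and so loses the gain seen with compound 2. Measured against benzyl, 4-nitrophenyl gives no change at the digits printed from compound 1 to compound 3 (within the scatter) and shows that not every aromatic ring in this place lowers the number. Still open, going by these compounds, is whether the kind of group or its place on the aromatic ring counts for more, which 4-hydroxyphenyl could help separate, and how an amine or a carboxylic acid there would behave. Nothing measured here explains these differences.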